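A Piperidine for a Piperazinone: Expectations for Compound 4

A few compounds are considered here, and "the series" means these few. Any claim that something is new, unique, unknown or untested is made for them only; others in the source may bear on it.

Measured compounds:
compound 1, `CN1CCN(CC(=O)NC2(c3ccc(Cl)cc3)C(=O)Nc3cc(Cl)ccc32)CC1`, 140 nM
compound 2, `CCN1CCN(CC(=O)NC2(c3ccc(Cl)c(Cl)c3)C(=O)Nc3cc(Cl)cc(Cl)c32)CC1=O`, 2780 nM
compound 3, `Cc1cc2c(cc1Cl)NC(=O)C2(NC(=O)CN1CCN(C)CC1)c1cccc(Cl)c1`, 1180 nM

Of the compounds shown here, three sharing a common core have been tested in an in vitro functional assay on CHO-CREluc cells for antagonist activity at growth hormone secretagogue receptor type 1 (Homo sapiens), read by a luciferase reporter, with a stated time of 4 h; on this read-out higher numbers stand for weaker inhibition and lower numbers for stronger inhibition. Compound 1 gives 140 nM, compound 3 gives 1180 nM, and compound 2 gives 2780 nM, the highest of the three numbers. The gap between compound 2 and compound 3 is beyond the usual scatter, and the gap between compound 2 and compound 1 is larger still and also beyond the scatter. Compound 2 is the weakest inhibitor of the set as it stands.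

Compound 4, `CN(C)C1CCN(CC(=O)NC2(c3ccc(Cl)c(Cl)c3)C(=O)Nc3cc(Cl)cc(Cl)c32)CC1`, has not yet been measured in this assay. It differs from compound 2 in a single place: 4-(dimethylamino)piperidin-1-yl in place of 4-ethyl-3-oxopiperazin-1-yl on a saturated chain carbon bound to a carbonyl carbon. Within the data shown here, no pair of measured compounds differs in exactly this way, so the size of the step can only be guessed from what the set shows. Compound 1 carries a simple piperazine arm and gives 140 nM, far below compound 2, which hints that an amine-bearing ring at this position may be favourable. Compound 4 is therefore expected to give a lower number than compound 2, with the step from compound 2 to compound 4 estimated at a 5.6-fold lower number from compound 2 to compound 4 (0.75 log units; beyond the scatter). Compound 4 is estimated to give 500 nM, within a range from 150 nM to 1800 nM.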

Compound 4, half-maximal inhibitory concentration: 239 nM
The estimate for compound 4 lay 2.1-fold (0.32 log units) above the measured number, and the stated range covers the measured number.
By their numbers in this assay, from the lowest: compounds 1 and 4 (each within the scatter of the next); then compound 3; then compound 2.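

In this assay, among these compounds, placing 4-(dimethylamino)piperidin-1-yl in place of 4-ethyl-3-oxopiperazin-1-yl on a saturated chain carbon bound to a carbonyl carbon gives a 12-fold lower number from compound 2 to compound 4 (1.07 log units; beyond the scatter), a large step and the first reading of this position with the rest of the molecule held constant. The position can therefore move the read-out strongly, even though the two groups have the same number of heavy atoms and the same counts of hydrogen-bond donors and acceptors; they differ in that the entering group has no double bond outside aromatic rings and one hetero atom in its ring, not two. No measurement offered here accounts for the size of this step.

The compounds shown leave open which part of the change carries the step, a question that groups such as 4-ethylpiperazin-1-yl, which lacks the ring carbonyl, or 4-aminopiperidin-1-yl, with a primary amine, could help to separate. They also leave open whether the same exchange gives a step of similar size on the differently chlorinated core of compound 1.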